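Swapping an anilino arm for a pyrrolidine ring

The source may report more compounds than this note shows. Statements on the series, on what has been measured and on what is new or still open speak of the compounds shown alone.

Of the compounds shown here, two built on a shared core have been tested in a functional assay on MCF7 cells (Homo sapiens) for inhibition, read by sulforhodamine B assay; a lower number here means a stronger inhibitor, a higher number a weaker inhibitor. Compound 1, `O=C1C(Nc2cccc(Cl)c2)=CC(=O)c2c1nc1n2[C@H]2OC[C@@H](O)[C@H]2OC1`, carries a (3-chlorophenyl)amino group on its core; in this assay compound 1 gives 2970 nM. Compound 2, `COc1cccc(NC2=CC(=O)c3nc4n(c3C2=O)[C@H]2OC[C@@H](O)[C@H]2OC4)c1`, carries a different aromatic amino group in that place. For compound 2 the assay reports only a limit, > 4000 nM, and not a number. Among the measured compounds shown here, compound 1 thus holds the only actual number among the two results, the other sitting at the limit (the limit of > 4000 nM in this assay, at which 1 of the 2 values shown sits). Compound 3, `O=C1C(N2CCCC2)=CC(=O)c2c1nc1n2[C@H]2OC[C@@H](O)[C@H]2OC1`, has not yet been measured. It differs from compound 1 in a single place: pyrrolidin-1-yl in place of (3-chlorophenyl)amino on a double-bonded ring carbon. For the measured compounds named here, no pair of measured compounds differing in one place is available, so the size of this step cannot be read from the data. Trading an aromatic ring that brings a hydrogen-bond donor for a small five-membered ring with no donor is a sizeable change, and a loss of potency beyond the usual scatter seems more likely than a gain. Compound 3 is expected to give about 4500 nM in this assay, within a range from 1500 nM to 15000 nM. The expected step is a 1.5-fold higher number from compound 1 to compound 3 (0.18 log units; within the scatter).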

Compound 3, half-maximal inhibitory concentration: > 16000 nM
Compound 3 ended at the assay's limit; the forecaster's own chance of this, stated with the estimate: 50%; middle value at least 3.5-fold (0.55 log units) from the limit.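

Among the compounds shown here, replacing (3-chlorophenyl)amino with pyrrolidin-1-yl on the double-bonded ring carbon gives an at least 5.3-fold higher number from compound 1 to compound 3 (0.73 log units; beyond the scatter) in this assay, the first step whose size can be read at all. It shows that this place on the shared core is sensitive to what is attached there, and that this particular swap weakens inhibition beyond ordinary measurement noise. The result for compound 3 is a limit of the assay and not a number: the limit of > 16000 nM in this assay, at which 1 of the 3 values shown sits.

The change removes an aromatic ring and a hydrogen-bond donor in a single move, and it also shifts the size of the group, so these compounds cannot show which of those differences matters. A cyclopentylamino group, which has a non-aromatic ring but retains the amino hydrogen, would help separate the role of the ring from that of the donor, while a phenyl ring joined to the core through a methylated amino nitrogen would test the reverse case.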